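Swapping an aromatic group for oxolan-3-yl

The source may hold more compounds than are shown below. What is called first, only, known or untested is meant among the compounds shown, and "the series" means these compounds.

Measured in a physicochemical assay for solubility, using the shake flask method, measured as kinetic solubility, with a stated time of 20 h, at pH 2; a lower number here means a less soluble compound, a higher number a more soluble compound:
Compound 1 `FC(F)(F)c1cccc(-c2nc3cnc(Nc4cnccn4)cc3[nH]2)c1`: 155000 nM
Compound 2 `FC(F)(F)c1ccc(Nc2cc3[nH]c(-c4cccc(C(F)(F)F)c4)nc3cn2)nc1`: < 5000 nM

Compound 2 gives no exact number. It stands at the limit of < 5000 nM in this assay, at which 1 of the 2 values shown sits, so only a limit is known for it. Compound 3 `FC(F)(F)c1ccc(Nc2cc3[nH]c(C4CCOC4)nc3cn2)nc1` has not yet been measured. It keeps the core of compound 2 and its 5-(trifluoromethyl)pyridin-2-yl group, but carries oxolan-3-yl in place of 3-(trifluoromethyl)phenyl on an aromatic carbon.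

Going by the values given here, only one measured step offers any guide, and it lies at a different place on the molecule. There, 5-(trifluoromethyl)pyridin-2-yl came in place of pyrazin-2-yl on a nitrogen on an aromatic ring. Here a group carrying trifluoromethyl leaves, whereas one entered with an at least 31-fold lower number from compound 1 to compound 2 (1.49 log units; beyond the scatter), so a clear move to a higher number is expected in this assay. This expectation rests on a single step at another place, so it remains loose. The expected change is an at least 8.0-fold higher number from compound 2 to compound 3 (0.90 log units; beyond the scatter). Compound 3 is estimated at 40000 nM, with an expected range from 8000 nM to 180000 nM.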

Compound 3, solubility: 200000 nM
Estimate against measurement, compound 3: 5.0-fold (0.70 log units) below, and the stated range ends below it.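

Replacing 3-(trifluoromethyl)phenyl with oxolan-3-yl on an aromatic carbon between two ring nitrogen atoms gives, in this assay, an at least 40-fold higher number from compound 2 to compound 3 (1.60 log units; beyond the scatter). Going by these compounds alone, the earlier step concerned only the group on a nitrogen, so this is the first sign that the read-out also responds strongly to the group at this second place, even with the 5-(trifluoromethyl)pyridin-2-yl group still in the molecule. The size of this step is itself only a bound, as the value for compound 2 is a limit: the limit of < 5000 nM in this assay, at which 1 of the 3 values shown sits.

This single swap cannot separate what each part of the change contributes: the loss of the trifluoromethyl group, the loss of the aromatic ring, and the arrival of the ring oxygen. From the compounds shown here alone, it remains open whether a plain phenyl, a cyclopentyl ring with no oxygen, or an amine at this place would give a similar result, and whether oxolan-3-yl would have a comparable effect with pyrazin-2-yl on the nitrogen.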